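The compounds below may be only part of what the source reports. "The series", "measured", "known", "first", "only" and "open" are said of these compounds alone.

Values measured so far in a functional assay (Platelet, plasma) for inhibition, with Homo sapiens as the target; on this read-out higher numbers stand for weaker inhibition and lower numbers for stronger inhibition

compound 1 `Cc1ccc(CS(=O)(=O)NC(=O)C2(F)CCN(c3nc4c(cc3C#N)C(=O)OC4)CC2)cc1` gives 32800 nM
compound 2 `CC(c1ccccc1)S(=O)(=O)NC(=O)C1(F)CCN(c2nc3c(cc2C#N)C(=O)OC3)CC1` gives 9950 nM

Of these two, compound 1 carries the higher number and is the weaker inhibitor of the pair. Compound 3 `Cc1ccc(CS(=O)(=O)NC(=O)C2CCN(c3nc4c(cc3C#N)C(=O)OC4)CC2)cc1` departs from compound 1 by hydrogen in place of fluoro on a saturated ring carbon on an otherwise shared structure: hydrogen in place of fluoro on a saturated ring carbon, three ring bonds from the ring nitrogen. Among the compounds with values here, only one measured step is available, and it is modest: a 3.3-fold lower number from compound 1 to compound 2 (0.52 log units; beyond the scatter) for a change of the group on the sulfonyl sulfur. Within the data shown here, that step concerns another part of the molecule, and no measured pair tests the fluoro on this ring carbon. It therefore offers a rough size for a single change, but no direction for this one. In this assay no step beyond the scatter is the most likely expectation, although a modest step of that size in either direction would fit the data. The expected change is a 1.2-fold lower number from compound 1 to compound 3 (0.08 log units; within the scatter) and so stays within the scatter. For compound 3 the estimated value is 27000 nM with an expected range from 9000 nM to 75000 nM in this measurement.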

Compound 3, half-maximal inhibitory concentration: 4280 nM
Estimate against measurement, compound 3: 6.3-fold (0.80 log units) above, and the stated range ends above it.
By their numbers in this assay, from the lowest: compound 3; then compound 2; then compound 1.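

The fluoro position had no measured test until compound 3, and in this assay the exchange of fluoro for hydrogen on this saturated ring carbon, three ring bonds from the ring nitrogen, moves the result clearly towards stronger inhibition (a 7.7-fold lower number from compound 1 to compound 3 (0.88 log units; beyond the scatter)). The fluoro is therefore not required for inhibition in this series, and with the 4-methylbenzyl group held constant its removal helps rather than harms, so this ring carbon responds to a one-atom change just as the group on the sulfonyl sulfur responds to a change (a 3.3-fold lower number from compound 1 to compound 2 (0.52 log units; beyond the scatter)). The data shown give no measurement that accounts for the direction or size of this step.

The compounds shown leave open whether the same exchange of fluoro for hydrogen would bring a comparable gain with the 1-phenylethyl group on the sulfonyl sulfur, since that pairing does not appear among them. They also leave open how this ring carbon would respond to a different substituent, such as a methyl group, a hydroxyl group or an amine, and so whether hydrogen is the best choice here.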